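The source may hold more compounds than are shown below. What is called first, only, known or untested is meant among the compounds shown, and "the series" means these compounds.

The series rests on a shared core, carried by compound 1 `O=S(=O)(Nc1nccs1)c1ccc2c(c1)OCC[C@@H]2c1ccc(C(F)(F)F)cc1-c1ccc(F)cn1`, compound 2 `Cc1ccc(-c2cc(C(F)(F)F)ccc2[C@H]2CCOc3cc(S(=O)(=O)Nc4ncc(F)cn4)ccc32)cn1` and compound 3 `Cn1nccc1-c1cc(C(F)(F)F)ccc1[C@H]1CCOc2cc(S(=O)(=O)Nc3cccnn3)ccc21`, each measured in a physicochemical assay for lipophilicity; a higher number here means a more lipophilic compound, a lower number a more polar compound. Compound 1 gives 3.5, compound 2 gives 2.5 and compound 3 gives 2.2. Among these three numbers compound 2 stands second highest: its nearest neighbour is compound 3, a value that lies within the scatter of it, while its furthest is compound 1, a value that lies beyond the scatter. No pair of these compounds differs in only one place, so no single-step comparison is available.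

Compound 4 `Cc1nc(-c2cc(C(F)(F)F)ccc2[C@H]2CCOc3cc(S(=O)(=O)Nc4ncc(F)cn4)ccc32)co1` has not yet been measured. It differs from compound 2 in one place: 2-methyl-1,3-oxazol-4-yl in place of 6-methylpyridin-3-yl on an aromatic carbon.

Going by the values given here, with no matching step in the data, the expectation can rest only on the three values and the change itself. The change from compound 2 to compound 4 is expected to lower the value in this assay by a modest amount, near the edge of the scatter, as the estimated step of a number 0.30 log units lower from compound 2 to compound 4 (within the scatter) expresses. Compound 4 is therefore estimated at 2.2, with a range from 1.8 to 2.7.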

Compound 4, distribution coefficient: 2.8
For compound 4 the middle estimate is 0.60 log units below the measured one; the whole stated range lies below it.
By their numbers in this assay, from the lowest: compounds 3, 2 and 4 (each within the scatter of the next, the first and the last beyond it); then compound 1.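

In this assay the only single-place comparison shown concerns an aromatic carbon ortho to a large group and meta to a trifluoromethyl group, where 2-methyl-1,3-oxazol-4-yl in place of 6-methylpyridin-3-yl gives a number 0.30 log units higher from compound 2 to compound 4 (within the scatter) so this measurement does not separate the two compounds. For this one pair, then, a five-membered aromatic ring with 2 hetero atoms and a six-membered aromatic ring with 1 hetero atom are not told apart at this position. Nothing available explains the size of this step.

Going by these compounds, whether a plain phenyl ring, a carboxylic acid or an aminomethyl group at this position would also stay within the scatter of compound 2 remains open. The compounds shown also leave open whether the same exchange would give a similar step on the rest of compound 1 or compound 3.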